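The compounds below may be only part of what the source reports. "The series", "measured", "known", "first", "only" and "open" are said of these compounds alone.

In a functional assay on HeLa cells (Homo sapiens) for antiproliferative activity, read by CCK-8 assay, with a stated time of 72 h (a lower number here means a stronger inhibitor, a higher number a weaker inhibitor), compound 1 `Cc1cc(Nc2cc(N3CCN(C)CC3)nc(Nc3ccc([N+](=O)[O-])cc3)n2)n[nH]1` gives 331 nM, the lowest of the three numbers measured. Compound 2 `Cc1cc(Nc2cc(N3CCN(C)CC3)nc(Nc3ccc(Cl)cc3)n2)n[nH]1` gives 619 nM, and compound 3 `Cc1cc(Nc2cc(N3CCN(C)CC3)nc(Nc3cccc([N+](=O)[O-])c3)n2)n[nH]1` gives 1110 nM. Swapping chloro in place of nitro on an aromatic carbon gave a 1.9-fold higher number from compound 1 to compound 2 (0.27 log units; within the scatter), while moving to 3-nitrophenyl in place of 4-nitrophenyl gave a 3.4-fold higher number from compound 1 to compound 3 (0.53 log units; beyond the scatter). Compound 4 `COc1ccc(Nc2nc(Nc3cc(C)[nH]n3)cc(N3CCN(C)CC3)n2)cc1` differs from compound 1 by methoxy in place of nitro on an aromatic carbon. The step from compound 1 to compound 2 is the only one that bears on this: another group replacing nitro on the same aromatic carbon, with a result within the scatter. Going by the values given here, no measured compound carries methoxy, so the expectation for compound 4 is a step of a 1.7-fold higher number from compound 1 to compound 4 (0.22 log units; within the scatter), within or near the scatter, giving an estimated 550 nM with a range from 220 nM to 1500 nM.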

Compound 4, half-maximal inhibitory concentration: 867 nM
Estimate against measurement, compound 4: 1.6-fold (0.20 log units) below; the measured number falls inside the stated range.
By their numbers in this assay, from the lowest: compounds 1, 2, 4 and 3 (each within the scatter of the next, the first and the last beyond it).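

Of the two replacements of nitro now shown on this aromatic carbon, para to a large group, only methoxy steps beyond the scatter, giving a 2.6-fold higher number from compound 1 to compound 4 (0.42 log units; beyond the scatter). Methoxy and chloro cannot be told apart here, with a 1.4-fold higher number from compound 2 to compound 4 (0.15 log units; within the scatter), and the 4-methoxyphenyl and 3-nitrophenyl compounds also stay level, with a 1.3-fold lower number from compound 3 to compound 4 (0.11 log units; within the scatter). No measurement here explains these differences.

Still open, from the compounds shown here alone, is whether an amine or a carboxylic acid on this carbon would match the nitro group of compound 1. Also open, going by these compounds, is whether a longer chain such as ethoxy would behave like methoxy.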